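Aryl variation on a shared core: outlook for compound 4

The compounds below may be only part of what the source reports. "The series", "measured", "known", "first", "only" and "open" are said of these compounds alone.

Measured so far in a functional assay for inhibition, tested at 20 ug/mL; a lower number here means a weaker effect, a higher number a stronger effect of the compound at the concentration tested:
compound 1 `Cc1cc(O)c(C(C)C)cc1-c1cc(-c2ccccc2)c(C#N)c(=O)[nH]1` gives 22%
compound 2 `COc1cc(-c2cc(-c3cc(C(C)C)c(O)cc3C)[nH]c(=O)c2C#N)ccc1O` gives 26%
compound 3 `Cc1cc(O)c(C(C)C)cc1-c1cc(-c2ccco2)c(C#N)c(=O)[nH]1` gives 26%

Compound 3 stands level with compound 2 at the digits printed, the two together the highest of the three numbers, with compound 1 the furthest: a number 4 percentage points higher from compound 1 to compound 3 (within the scatter). Between compounds 2 and 3 there is no change at the digits printed from compound 2 to compound 3 (within the scatter). The three aryl groups so far have therefore not moved the read-out beyond the scatter.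

Compound 4 `COc1ccc(-c2cc(-c3cc(C(C)C)c(O)cc3C)[nH]c(=O)c2C#N)cc1OC` is not yet measured. It differs from compound 3 as follows: 3,4-dimethoxyphenyl in place of furan-2-yl on an aromatic carbon

Going by the values given here, two measured steps bear on this change. The exchange of phenyl for 4-hydroxy-3-methoxyphenyl gave a number 4 percentage points higher from compound 1 to compound 2 (within the scatter), and the exchange of 4-hydroxy-3-methoxyphenyl for furan-2-yl gave no change at the digits printed from compound 2 to compound 3 (within the scatter). A six-membered aryl carrying two oxygen substituents is thus already represented by compound 2, which sits level with compound 3. Among the compounds with values here, no step here is beyond the scatter, so for compound 4 a step of a number 1 percentage points lower from compound 3 to compound 4 (within the scatter) is expected, that is, none beyond the scatter in either direction. Compound 4 is accordingly estimated at 25%, within the range 12% to 38%.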

Compound 4, a percentage reported as inhibition, at one concentration (the size of the read-out at that concentration, not a potency): 25%
The estimate for compound 4 equals the measured number at the digits printed; the measured number falls inside the stated range.
By their numbers in this assay, from the lowest: compounds 1, 4, 2 and 3 (each within the scatter of the next).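

Working notes: in this assay, a six-membered aromatic ring of carbon only, as 3,4-dimethoxyphenyl, replaces the five-membered aromatic ring of furan-2-yl on the aromatic carbon ortho to a cyano group and opposite the ring nitrogen, giving a number 1 percentage points lower from compound 3 to compound 4 (within the scatter), so the read-out at this position does not separate these two ring types. Methyl in place of hydrogen on the ring oxygen gives a number 1 percentage points lower from compound 2 to compound 4 (within the scatter), which shows that the free hydroxy group of compound 2 is not needed to hold the read-out here, and the two methoxy groups together, set against plain phenyl, give a number 3 percentage points higher from compound 1 to compound 4 (within the scatter). No measurement on hand offers an explanation for these steps.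

From the compounds shown here alone, whether any group at this position can move the read-out beyond the scatter stays open, for instance an aryl bearing an amine or a carboxylic acid, or a longer alkyl chain in place of the aryl ring. Also open is whether the nitrile or the isopropyl group on the other aryl ring contributes to the read-out at all, and a single-concentration percentage gives no potency for any of these compounds.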